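The source may hold more compounds than are shown below. What is called first, only, known or untested is meant among the compounds shown, and "the series" means these compounds.

Values in a functional assay on HeLa cells (Homo sapiens) for inhibition, read by sulforhodamine B assay; on this read-out lower numbers stand for stronger inhibition and higher numbers for weaker inhibition:

Compound 1 `CCCc1ccc(NC2=CC(=O)c3nc4n(c3C2=O)[C@H]2OC[C@@H](O)[C@H]2OC4)cc1`: 4990 nM
Compound 2 `COc1ccccc1NC1=CC(=O)c2c(nc3n2[C@H]2OC[C@@H](O)[C@H]2OC3)C1=O`: 7460 nM
Compound 3 `CCc1ccc(NC2=CC(=O)c3nc4n(c3C2=O)[C@H]2OC[C@@H](O)[C@H]2OC4)cc1`: 3990 nM

In this assay, compound 3 at 3990 nM lies within the scatter of both compound 1 and compound 2, so these values do not separate it from either neighbour. The next compound, compound 4 `COc1ccc(NC2=CC(=O)c3nc4n(c3C2=O)[C@H]2OC[C@@H](O)[C@H]2OC4)cc1`, differs from compound 3 by methoxy in place of ethyl on an aromatic carbon, with methoxy in place of ethyl on an aromatic carbon.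

For the measured compounds named here, only one measured step bears on this change, and only indirectly: a 1.3-fold lower number from compound 1 to compound 3 (0.10 log units; within the scatter), a small change to the chain at the same place that stays within the scatter. Compound 2, which also carries a methoxy group on an aromatic carbon, gives 7460 nM, and this is no direct test of the change. With so little evidence, no shift beyond the scatter is expected in this assay, and the expected step is a 1.1-fold higher number from compound 3 to compound 4 (0.05 log units; within the scatter). For compound 4 the estimated value is 4500 nM, with an expected range from 2200 nM to 9000 nM.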

Compound 4, half-maximal inhibitory concentration: 4780 nM
Compound 4: the middle estimate sits 1.1-fold (0.03 log units) below what was measured; low and high end bracket the measured number.
By their numbers in this assay, from the lowest: compounds 3, 4, 1 and 2 (each within the scatter of the next).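

In this assay, methoxy in place of ethyl on the aromatic carbon para to a large group gives a 1.2-fold higher number from compound 3 to compound 4 (0.08 log units; within the scatter), and methoxy in place of propyl at the same carbon gives a 1.0-fold lower number from compound 1 to compound 4 (0.02 log units; within the scatter). The earlier step compared only two carbon chains, whereas these show that a group with oxygen and a hydrogen-bond acceptor, which ethyl and propyl lack, cannot be told apart from either chain at this position in this assay. No measurement shown here offers an explanation for this result.

What the compounds shown leave open is whether anything placed on this carbon moves the number beyond the scatter, as no step among them does. From the compounds shown here alone, an amine, a carboxylic acid or a much longer chain at this position would test that, and the limits of this tolerance remain unknown.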